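Moving from 3,4-dihydroxyphenyl to 2,4-dichlorophenyl

The source may hold more compounds than are shown below. What is called first, only, known or untested is meant among the compounds shown, and "the series" means these compounds.

In a functional assay on MCF7 cells (Homo sapiens) for cytotoxicity, read by MTT assay, with a stated time of 48 h (on this read-out higher numbers stand for weaker inhibition and lower numbers for stronger inhibition), compound 1 `O=C(CSc1nnc(-c2ccncc2)o1)N/N=C/c1cc(Br)ccc1O` gives 7770 nM and compound 2 `O=C(CSc1nnc(-c2ccncc2)o1)N/N=C/c1ccc(O)c(O)c1` gives 910 nM as the lower of the two numbers. Going by the values given here, the one measured step is an 8.5-fold lower number from compound 1 to compound 2 (0.93 log units; beyond the scatter) and it is the only guide to the next change. Compound 3 `O=C(CSc1nnc(-c2ccncc2)o1)N/N=C/c1ccc(Cl)cc1Cl` shares the core of compound 2 and differs at one place, with 2,4-dichlorophenyl in place of 3,4-dihydroxyphenyl on a carbon with a double bond to nitrogen as the counted change. The entering group carries halogen, as does the 5-bromo-2-hydroxyphenyl of compound 1, which stands at 7770 nM on the higher side. A single step is a thin basis, but a move of similar or somewhat smaller size toward a higher number is expected. The expected change is a 4.4-fold higher number from compound 2 to compound 3 (0.64 log units; beyond the scatter) as a working estimate. For compound 3 the estimated value is 4000 nM within an expected range of 1200 nM to 13000 nM in this assay.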

Compound 3, half-maximal inhibitory concentration: 27900 nM
Compound 3: middle estimate off by 7.0-fold (0.84 log units), on the low side, and the stated range ends below it.
By their numbers in this assay, from the lowest: compound 2; then compound 1; then compound 3.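

In this assay, the position on a carbon with a double bond to nitrogen now shows a much wider spread: 2,4-dichlorophenyl in place of 3,4-dihydroxyphenyl gives a 31-fold higher number from compound 2 to compound 3 (1.49 log units; beyond the scatter), a large step. Replacing 5-bromo-2-hydroxyphenyl with 2,4-dichlorophenyl gives a 3.6-fold higher number from compound 1 to compound 3 (0.56 log units; beyond the scatter), so the numbers among these three compounds rise from the dihydroxyphenyl through the bromo-hydroxyphenyl to the dichlorophenyl, which has no hydroxyl group, and none of the three goes against this order. No measurement at hand gives a reason for either step.

Hydroxyl and halogen change together across these compounds, so their contributions remain unseparated. A phenyl ring carrying methoxy groups or an amino group would show whether the hydroxyl groups themselves matter at this position.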